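The compounds below may be only part of what the source reports. "The series", "measured", "known", "first", "only" and "open" are said of these compounds alone.

In a functional assay on A549 cells (Homo sapiens) for antiproliferative activity, read by MTT assay, with a stated time of 72 h (a higher number here means a weaker inhibitor, a lower number a stronger inhibitor), compound 2 `O=C1O[C@H]([C@@H](O)Cn2cc(CCCCl)nn2)C(OCc2ccccc2)=C1OCc1ccccc1` gives 29000 nM, the highest of the two plain numbers in this small set. Compound 1 `CCCCCCCCCCc1cn(C[C@H](O)[C@H]2OC(=O)C(OCc3ccccc3)=C2OCc2ccccc2)nn1` gives 6750 nM. Compound 3 `O=C1O[C@H]([C@@H](O)Cn2ccnn2)C(OCc2ccccc2)=C1OCc1ccccc1` gives > 100000 nM, which is a limit of the assay and not a number. That reading sits at the limit of > 100000 nM in this assay, at which 1 of the 3 values shown sits.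

Among the measured compounds shown here, two measured steps bear on the place where compound 2 is about to be changed. The step of a 4.3-fold higher number from compound 1 to compound 2 (0.63 log units; beyond the scatter) shows that shortening the chain on the triazole goes with a weaker inhibitor, and the step of an at least 3.4-fold higher number from compound 2 to compound 3 (0.53 log units; beyond the scatter) points the same way when the chain is removed altogether; the step of an at least 14-fold higher number from compound 1 to compound 3 (1.17 log units; beyond the scatter) spans both. Across these three compounds, a larger group at this position goes with a lower number, though only three points support that trend.

Compound 4 `O=C1O[C@H]([C@@H](O)Cn2cc(CNS(=O)(=O)c3ccc(Cl)cc3F)nn2)C(OCc2ccccc2)=C1OCc1ccccc1` has not yet been measured. It differs from compound 2 in one place: ((4-chloro-2-fluorophenyl)sulfonyl)amino in place of 2-chloroethyl on a saturated chain carbon bound to an aromatic carbon. For the measured compounds named here, the entering group is much larger than the 2-chloroethyl it replaces, yet it is of a different kind, with a sulfonamide and a second aromatic ring, and no measured step tests anything like it. On the size trend alone a lower number is expected, and the estimated step is a 2.9-fold lower number from compound 2 to compound 4 (0.46 log units; beyond the scatter), modest in size. The estimate for compound 4 is therefore 10000 nM, with a range from 3000 nM to 40000 nM.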

Compound 4, half-maximal inhibitory concentration: 39100 nM
Estimate against measurement, compound 4: 3.9-fold (0.59 log units) below; the range from low to high includes it.
By their numbers in this assay, from the lowest: compound 1; then compounds 2 and 4 (each within the scatter of the next). At a limit, above all of these: compound 3.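

The sulfonamide group of compound 4, with its aromatic ring, is far larger than the 2-chloroethyl it replaces, yet in this assay this change gives a 1.3-fold higher number from compound 2 to compound 4 (0.13 log units; within the scatter), so compound 2 and compound 4 cannot be told apart. Compound 4 therefore goes against the trend seen in compounds 1, 2 and 3, where a larger group went with a lower number, and size alone does not set the number at this position. The long plain carbon chain keeps its place ahead of this bulkier, ring-bearing group, as the step of a 5.8-fold higher number from compound 1 to compound 4 (0.76 log units; beyond the scatter) shows, so a group can be large here and still give no gain over the short chloroalkyl chain of compound 2, and nothing measured here gives a reason for this result.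

Among the compounds shown here, with only one group of this kind, it remains unknown whether the sulfonamide link or the halogenated aromatic ring sets this reading. Going by these compounds, it is also open whether a dodecyl chain would go further than compound 1, or whether a simple benzyl group or a chain ending in an amine or a carboxylic acid would fit the trend.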